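Swapping a methylphenyl for a pyrrole on a shared core

A few compounds are considered here, and "the series" means these few. Any claim that something is new, unique, unknown or untested is made for them only; others in the source may bear on it.

Two measured compounds share the same core and differ in the group attached to it. Compound 1 `C#CCSc1nc(Sc2nccs2)c(C#N)c(-c2ccc(C)cc2)n1` carries a 4-methylphenyl group, and in a functional assay on PC-9 cells (Homo sapiens) for antiproliferative activity, read by MTT assay (on this read-out higher numbers stand for weaker inhibition and lower numbers for stronger inhibition), compound 1 gives 1110 nM. Compound 2 `C#CCSc1nc(Sc2nncs2)c(C#N)c(-c2cc(OC)c(OC)c(OC)c2)n1` differs from compound 1 at two places rather than one, and in this assay compound 2 gives 7960 nM. Compound 1 thus stands lowest of the two numbers, with compound 2 lying well beyond the scatter above it.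

Compound 3 `C#CCSc1nc(Sc2nccs2)c(C#N)c(-c2ccc[nH]2)n1` has not been measured. It differs from compound 1 in one way: 1H-pyrrol-2-yl in place of 4-methylphenyl on an aromatic carbon. Within the data shown here, no measured pair tracks this exact change, so its effect is uncertain; a small weakening is expected, though a step within the scatter is also plausible. The expected step of a 2.0-fold higher number from compound 1 to compound 3 (0.30 log units; within the scatter) is modest. For compound 3 in this assay the estimate is 2200 nM, within a range from 600 nM to 8000 nM.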

Compound 3, half-maximal inhibitory concentration: > 20000 nM
Compound 3 ended at the assay's limit (the forecaster's own chance of this, stated with the estimate: 5%); middle value at least 9.0-fold (0.95 log units) from the limit.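

In this assay, the value of compound 3, > 20000 nM, is a limit of the assay and not a true number. Exchanging 4-methylphenyl for 1H-pyrrol-2-yl gives an at least 18-fold higher number from compound 1 to compound 3 (1.25 log units; beyond the scatter), the first single-place change seen here, and it shows that this position, next to the ring nitrogen and ortho to a cyano group, does not accept every aromatic ring equally. The true step could be larger still, and the result should be read with this in mind: the limit of > 20000 nM in this assay, at which 1 of the 3 values shown sits.

The compounds shown cannot separate the effect of the smaller ring from that of its ring nitrogen and the hydrogen on it. Plain phenyl or 1-methylpyrrol-2-yl at this position would help tell these apart, and how either would behave remains open.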